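Triazolopyrimidine series: aryl-amine to benzyl-amine swap

The compounds below may be only part of what the source reports. "The series", "measured", "known", "first", "only" and "open" are said of these compounds alone.

Measured so far:
compound 1 `c1ccc(Cn2nnc3c(NC4CCCCC4)ncnc32)cc1`: 121 nM
compound 2 `Cc1ccc(Nc2ncnc3c2nnn3Cc2ccccc2Cl)cc1`: 119 nM

In an assay on cell membranes for binding affinity to adenosine receptor A1 (Bos taurus), read by radioligand binding (on this read-out lower numbers stand for stronger inhibition and higher numbers for weaker inhibition), compound 1 gives 121 nM and compound 2 gives 119 nM; the two numbers sit within the usual scatter of each other, so no order between them can be read. Compound 3 `Nc1ccc(CNc2ncnc3c2nnn3Cc2ccccc2Cl)cc1` is yet to be measured in this assay. It differs from compound 2 in one place: 4-aminobenzyl in place of 4-methylphenyl on a nitrogen on an aromatic ring. Among the measured compounds shown here, no pair of measured compounds shows the effect of such a change, so no measured step gives guidance. For the measured compounds named here, only the structural change itself can be weighed, and a change of this kind on the nitrogen on an aromatic ring has, across the two compounds measured here, no precedent. The expectation is therefore a modest shift toward a higher number, with wide uncertainty in both directions. For compound 3 the estimated value in this assay is 250 nM, with a range from 60 nM to 1000 nM, corresponding to an expected step of a 2.1-fold higher number from compound 2 to compound 3 (0.32 log units; beyond the scatter).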

Compound 3, inhibition constant: > 1000 nM
Compound 3: only a limit was reported (the forecaster's own chance of this, stated with the estimate: 5%); at least 4.0-fold (0.60 log units) between middle value and limit.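

In this assay compound 3 gives > 1000 nM, which is a limit of the assay and not a number. Placing 4-aminobenzyl in place of 4-methylphenyl on a nitrogen on an aromatic ring gives the first measured step in the series, an at least 8.4-fold higher number from compound 2 to compound 3 (0.92 log units; beyond the scatter), and shows that this position does not accept every group carrying a six-membered aromatic ring equally well. Only a lower bound on the size of this step can be read: the limit of > 1000 nM in this assay, at which 1 of the 3 values shown sits.

The step combines two differences, the added carbon link to the ring and the amine in place of the methyl, and the compounds shown leave open which of them matters. A 4-aminophenyl or an unsubstituted benzyl on this nitrogen would separate the two.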